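The source may hold more compounds than are shown below. What is called first, only, known or untested is meant among the compounds shown, and "the series" means these compounds.

Of the compounds shown here, three built on one shared core have been measured so far. Compound 1 is `Nc1scc(CN2CCN(c3ccc(Cl)cc3Cl)CC2)c1C(=O)c1ccc(Cl)cc1`, compound 2 is `Nc1scc(CN2CCN(c3cccc(Cl)c3Cl)CC2)c1C(=O)c1ccc(Cl)cc1` and compound 3 is `Nc1scc(CN2CCN(c3ccc(Cl)cc3F)CC2)c1C(=O)c1ccc(Cl)cc1`. In a functional assay on CHO cells with adenosine receptor A1 (Homo sapiens) as the target, read by cAMP accumulation and immunoassay, with a stated time of 6 min, tested at 1 uM (a lower number here means a stronger effect, a higher number a weaker effect of the compound at the concentration tested), compound 1 gives -54%, compound 2 gives -57% and compound 3 gives -57%. Compound 3 therefore stands level with compound 2 at the digits reported, the two together being the lowest of the three numbers, and the steps of no change at the digits printed from compound 2 to compound 3 (within the scatter) and a number 3 percentage points lower from compound 1 to compound 3 (within the scatter) both stay inside the scatter of repeated measurements. The step of a number 3 percentage points lower from compound 1 to compound 2 (within the scatter) also stays inside it.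

The next compound, compound 4, is `Nc1scc(CN2CCN(c3cccc(F)c3)CC2)c1C(=O)c1ccc(Cl)cc1`. Compared with compound 3 the difference is 3-fluorophenyl in place of 4-chloro-2-fluorophenyl on an amine nitrogen in a ring.

Each measured step changed the aromatic ring that hangs on the amine nitrogen in a ring, either by moving or swapping its halogens, and none of them moved the read-out beyond the scatter. The change to compound 4 is of the same kind, removing one chlorine and relocating one fluorine on that ring. The expected step is therefore a number 1 percentage points higher from compound 3 to compound 4 (within the scatter), nothing beyond the scatter. For compound 4 in this assay the estimate is -56%, expected to lie between -70% and -42%.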

Compound 4, a percentage reported as activity, at one concentration (the size of the read-out at that concentration, not a potency): -86%
Compound 4: middle estimate off by 30 percentage points, on the high side; measured number below the stated range.
By their numbers in this assay, from the lowest: compound 4; then compounds 2, 3 and 1 (each within the scatter of the next).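

Until now, swapping halogens on the aromatic ring on the amine nitrogen in a ring left this assay unmoved, so this position could have seemed indifferent to such changes. Compound 4 shows otherwise, with a number 29 percentage points lower from compound 3 to compound 4 (beyond the scatter) and a number 29 percentage points lower from compound 2 to compound 4 (beyond the scatter) and also a number 32 percentage points lower from compound 1 to compound 4 (beyond the scatter) all beyond the scatter, so the read-out at this position does respond to what the ring carries. The three earlier rings all bear chlorine while 3-fluorophenyl bears fluorine alone, but no measurement here explains the shift in the read-out.

This single compound cannot separate the loss of chlorine from the new place of the fluorine, since 3-fluorophenyl differs from each earlier ring in more than one way. As far as these compounds go, it also remains open how a plain phenyl ring would read at this position, or a ring carrying a methoxy group or an amine in place of the fluorine, and so whether the stronger effect belongs to fluorine itself or simply to the absence of chlorine.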